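A few compounds are considered here, and "the series" means these few. Any claim that something is new, unique, unknown or untested is made for them only; others in the source may bear on it.

In a functional assay on MGC-803 cells (Homo sapiens) for inhibition, read by sulforhodamine B assay (on this read-out higher numbers stand for weaker inhibition and lower numbers for stronger inhibition), compound 1 (`COc1ccc(NC2=CC(=O)c3c(nc4n3[C@H]3OC[C@@H](O)[C@H]3OC4)C2=O)cc1`) gives 2150 nM and compound 2 (`CCCc1ccc(NC2=CC(=O)c3c(nc4n3[C@H]3OC[C@@H](O)[C@H]3OC4)C2=O)cc1`) gives 1920 nM so the two sit within the scatter of each other and cannot be ranked. For the measured compounds named here, compound 2 therefore stands level with the only other number. The next compound is compound 3 (`O=C1C(Nc2cccc(Cl)c2)=CC(=O)c2c1nc1n2[C@H]2OC[C@@H](O)[C@H]2OC1`), with 3-chlorophenyl in place of 4-propylphenyl on an amine nitrogen. The shared core stays the same. Going by the values given here, one measured step bears on this change: propyl in place of methoxy on an aromatic carbon (a 1.1-fold lower number from compound 1 to compound 2 (0.05 log units; within the scatter)), which lies within the scatter. That is a single pair, and it changes a group on the aromatic ring while the ring stays in the same place. Among the compounds with values here, no chlorine-bearing compound has been measured yet, so the evidence is thin and the range must stay wide. No step beyond the scatter is expected in this assay, in either direction. The estimated move is small (a 1.0-fold higher number from compound 2 to compound 3 (0.02 log units; within the scatter)). Compound 3 is expected at 2000 nM (estimated range 800 nM to 5000 nM).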

Compound 3, half-maximal inhibitory concentration: 1530 nM
Beside the measured number, compound 3's estimate is 1.3-fold (0.12 log units) above it, and the stated range covers the measured number.
By their numbers in this assay, from the lowest: compounds 3, 2 and 1 (each within the scatter of the next).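

In this assay, 3-chlorophenyl in place of 4-propylphenyl on the amine nitrogen gives a 1.3-fold lower number from compound 2 to compound 3 (0.10 log units; within the scatter), and 3-chlorophenyl in place of 4-methoxyphenyl gives a 1.4-fold lower number from compound 1 to compound 3 (0.15 log units; within the scatter), so neither exchange separates the compounds. Compounds 1 and 2 varied only the group at the 4 position of the phenyl ring, whereas compound 3 brings in chlorine and moves the substituent to the 3 position, and the read-out of all three compounds still cannot be ranked. No measurement here bears on the reason for this insensitivity at the amine nitrogen.

Still open, as far as these compounds go, is whether this holds for a phenyl ring carrying a carboxylic acid or a dimethylamino group, or for a cyclohexyl group or a longer alkyl chain in place of the phenyl ring on the amine nitrogen. With all three compounds sharing one core and read in a single cell line, the compounds shown also leave open whether the same tolerance would appear with a changed core or in another assay.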